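Tetrazolylphenyl in place of pyridinyl on the amine nitrogen

A few compounds are considered here, and "the series" means these few. Any claim that something is new, unique, unknown or untested is made for them only; others in the source may bear on it.

Compound 1, `Clc1cc(Cl)cc(CO[C@H]2CCCN(Cc3ccncc3)[C@H]2c2ccccc2)c1` — in an assay on isolated protein for activation of cGMP-dependent protein kinase 1 (Homo sapiens), read by ADP-Glo, with stated times of 120 min and 40 min (on this read-out lower numbers stand for an effect already at smaller amounts and higher numbers for an effect only at larger amounts of compound), compound 1 reaches only the limit > 200000 nM.
Compound 2, `Clc1cc(Cl)cc(CO[C@H]2CCCN(Cc3ccccn3)[C@H]2c2ccccc2)c1` — in this assay compound 2 also reaches only the limit > 200000 nM.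
Compound 3, `OC[C@@H](O[C@H]1CCCN(Cc2cccc3nonc23)[C@H]1c1ccccc1)c1cc(Cl)cc(Cl)c1` — in this assay compound 3 gives 8000 nM.

Compound 2 therefore stands at a limit and not at a number; it shares this with compound 1, as the limit of > 200000 nM in this assay, at which 2 of the 3 values shown sit, records, while compound 3 alone carries a measured value. Among the measured compounds shown here, the one step among the measured compounds, a step that the two limits leave unreadable from compound 1 to compound 2, runs between two limits and its size cannot be read. For the measured compounds named here, compound 3 differs from compound 2 in more than one place, so its value shows only that a number within the assay's range is possible for this core.

The unmeasured compound 4, `Clc1cc(Cl)cc(CO[C@H]2CCCN(Cc3ccc(-c4nn[nH]n4)cc3)[C@H]2c2ccccc2)c1`, differs from compound 2 as follows: 4-(2H-tetrazol-5-yl)phenyl in place of pyridin-2-yl on a saturated chain carbon bound to an amine nitrogen in a ring.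

Going by the values given here, no measured step bears on this change, and the step from compound 1 to compound 2 gives no size to lean on. The account therefore expects compound 4 to stay near the limit, with a step of an at least 1.3-fold lower number from compound 2 to compound 4 (0.12 log units; that floor lies within the scatter) that is uncertain in both size and direction. Compound 4 is estimated at 150000 nM, within 30000 nM to 500000 nM, and a limit rather than a number is thought the more likely outcome.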

Compound 4, half-maximal effective concentration: 74000 nM
Compound 4: the middle estimate sits 2.0-fold (0.31 log units) above what was measured, within the range that was stated.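

Of the three groups shown at this place on the shared core, only 4-(2H-tetrazol-5-yl)phenyl gives a number rather than a limit in this assay. Setting it on the saturated chain carbon bound to the amine nitrogen in the ring brings an at least 2.7-fold lower number from compound 2 to compound 4 (0.43 log units; beyond the scatter), and it brings an at least 2.7-fold lower number from compound 1 to compound 4 (0.43 log units; beyond the scatter); each size is a floor, and the real gap may be wider, but this is the first readable evidence that a change at this place can move the read-out at all. The two pyridinyl compounds stay at a limit of the assay, and the step between them cannot be read: the limit of > 200000 nM in this assay, at which 2 of the 4 values shown sit.

From the compounds shown here alone, what remains open is which part of the entering group matters, the carbon-only six-membered ring or the tetrazole, and whether a plain phenyl or a carboxylic acid on that ring would serve in the same way. Compound 3, at 8000 nM, differs from compound 4 in more than one place, so how its changes relate to this one also stays unresolved.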